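The source may hold more compounds than are shown below. What is called first, only, known or untested is meant among the compounds shown, and "the series" means these compounds.

Compound 3 `COC(=O)c1cc(-c2cccc(NC(=O)c3ccc(/C=C/C(=O)c4cccc(OC)c4)cc3)c2)on1` carries a 3-methoxyphenyl on a carbonyl carbon of the shared core. In an ADME assay on Vero cells (Chlorocebus sabaeus) for cytotoxicity, read by MTT assay, with a stated time of 72 h (a lower number here means that less compound is tolerated, a higher number that more compound is tolerated), compound 3 gives > 100 ug/mL, which is a limit of the assay rather than a number. Compound 1 `COC(=O)c1cc(-c2cccc(NC(=O)c3ccc(/C=C/C(=O)c4ccccc4C)cc3)c2)on1`, with 2-methylphenyl on that carbonyl carbon, gives in this assay > 25 ug/mL, again a limit. Compound 2 `COC(=O)c1cc(-c2cccc(NC(=O)c3ccc(/C=C/C(=O)c4cccnc4)cc3)c2)on1` has "not determined" (no result reported) in this assay. The step that the two limits leave unreadable from compound 1 to compound 3 stays unreadable because both ends sit at limits the limit of > 100 ug/mL in this assay, at which 1 of the 3 values shown sits (the limit of > 25 ug/mL in this assay, at which 1 of the 3 values shown sits). Compound 4 `COC(=O)c1cc(-c2cccc(NC(=O)c3ccc(/C=C/C(=O)c4cccc([N+](=O)[O-])c4)cc3)c2)on1` differs from compound 3 by nitro in place of methoxy on an aromatic carbon. Among the measured compounds shown here, no measured step bears on this change, and the one comparable pair gives no readable size. Compound 4 is expected to be tolerated much like compound 3. The estimated step for compound 4 is a number no higher from compound 3 to compound 4 (the limit leaves the size open). Compound 4 is expected at 100 ug/mL, with a range from 40 ug/mL to 200 ug/mL.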

Compound 4, half-maximal cytotoxic concentration: > 40 ug/mL
Compound 4: a limit, no number; the forecaster's own chance of this, stated with the estimate: 65%; the middle value lies beyond the limit too.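

Compound 4 gives > 40 ug/mL, a limit and not a number. Among the compounds shown here, compound 1 and compound 3 also stand at limits, and no step among compound 1, compound 3 and compound 4 can be read. The compounds shown leave open whether the group on the carbonyl carbon changes the result in this assay at all.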